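Arylamine swap on the shared core: methyl to chlorine

The compounds below may be only part of what the source reports. "The series", "measured", "known", "first", "only" and "open" are said of these compounds alone.

Measured so far in a functional assay on HGC-27 cells (Homo sapiens) for cytotoxicity, read by MTT assay, with a stated time of 72 h; on this read-out higher numbers stand for weaker inhibition and lower numbers for stronger inhibition:
compound 1 `CCCCCCCCNc1nc(SCc2ccc(C(F)(F)F)cc2)nc2ccccc12` gives 13400 nM;
compound 2 `CCOc1ccccc1Nc1nc(SCc2ccc(C(F)(F)F)cc2)nc2ccccc12` reaches only a limit of the assay, > 50000 nM;
compound 3 `Cc1ccccc1Nc1nc(SCc2ccc(C(F)(F)F)cc2)nc2ccccc12` gives 27500 nM.

Among the two real numbers, compound 3 stands highest, with compound 1 as its nearest neighbour; that step, a 2.1-fold higher number from compound 1 to compound 3 (0.31 log units; beyond the scatter), is modest. Among the measured compounds shown here, the only other value is a limit (the limit of > 50000 nM in this assay, at which 1 of the 3 values shown sits).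

Compound 4 `FC(F)(F)c1ccc(CSc2nc(Nc3cccc(Cl)c3)c3ccccc3n2)cc1` differs from compound 3 in one place: 3-chlorophenyl in place of 2-methylphenyl on a nitrogen on an aromatic ring. For the measured compounds named here, the measured step that alters the aryl substituent, an at least 1.8-fold lower number from compound 2 to compound 3 (0.25 log units; that floor lies within the scatter), has a floor inside the scatter, and no measured step introduces chlorine. The expected step of a 1.0-fold lower number from compound 3 to compound 4 (0.01 log units; within the scatter) is therefore none beyond the scatter. Compound 4 is estimated at 27000 nM, between 11000 nM and 60000 nM.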

Compound 4, half-maximal inhibitory concentration: 19900 nM
Estimate against measurement, compound 4: 1.4-fold (0.13 log units) above; low and high end bracket the measured number.
By their numbers in this assay, from the lowest: compounds 1, 4 and 3 (each within the scatter of the next, the first and the last beyond it). At a limit, above all of these: compound 2.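

In this assay, among the compounds shown here, 3-chlorophenyl is the first aryl group here to stay within the scatter of the octyl chain (a 1.5-fold higher number from compound 1 to compound 4 (0.17 log units; within the scatter)), and it also stays within the scatter of 2-methylphenyl (a 1.4-fold lower number from compound 3 to compound 4 (0.14 log units; within the scatter)). Replacing 2-ethoxyphenyl gives a change beyond the scatter (an at least 2.5-fold lower number from compound 2 to compound 4 (0.40 log units; beyond the scatter)). That size is only a floor, as compound 2 is a limit and not a number: the limit of > 50000 nM in this assay, at which 1 of the 4 values shown sits.

Open, going by these compounds, is whether the chlorine or its place on the ring matters more, which 3-methylphenyl and 2-chlorophenyl would help separate. Also open, on these data alone, is how an aryl ring carrying a carboxylic acid would compare.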